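The source may report more compounds than this note shows. Statements on the series, on what has been measured and on what is new or still open speak of the compounds shown alone.

Measured compounds in an ADME assay on HT-29 cells (Homo sapiens) for inhibition, read by MTT assay, with a stated time of 72 h; a lower number here means a stronger inhibitor, a higher number a weaker inhibitor:
compound 1 `CN(C)C/C=C/C(=O)Nc1cccc(Nc2nc(N/N=C/c3c[nH]c4ccccc34)ncc2Cl)c1`, 9680 nM;
compound 2 `COc1ccc(/C(C)=N/Nc2ncc(Cl)c(Nc3cccc(NC(=O)/C=C/CN(C)C)c3)n2)cc1`, 6830 nM;
compound 3 `COc1cccc(/C(C)=N/Nc2ncc(Cl)c(Nc3cccc(NC(=O)/C=C/CN(C)C)c3)n2)c1`, 3870 nM.

Compound 3 has the lowest of the three numbers, yet its separation from compound 2 lies within the scatter (a 1.8-fold lower number from compound 2 to compound 3 (0.25 log units; within the scatter)), and only the gap to compound 1 is beyond it (a 2.5-fold lower number from compound 1 to compound 3 (0.40 log units; beyond the scatter)). Compound 4 `C/C(=N\Nc1ncc(Cl)c(Nc2cccc(NC(=O)/C=C/CN(C)C)c2)n1)c1cccnc1` differs from compound 3 in one place: pyridin-3-yl in place of 3-methoxyphenyl on a carbon with a double bond to nitrogen. Within the data shown here, no measured step exchanges the six-membered aromatic ring of carbon only at this position for a ring with a hetero atom. Among the measured compounds shown here, the nearest precedent is the change from 4-methoxyphenyl to 3-methoxyphenyl, a 1.8-fold lower number from compound 2 to compound 3 (0.25 log units; within the scatter), within the scatter; the larger replacements a 1.4-fold lower number from compound 1 to compound 2 (0.15 log units; within the scatter) and a 2.5-fold lower number from compound 1 to compound 3 (0.40 log units; beyond the scatter) were modest at most. Accordingly no step beyond the scatter is expected in this assay, a 1.3-fold higher number from compound 3 to compound 4 (0.11 log units; within the scatter). Compound 4 is estimated at 5000 nM, with a range of 2000 nM to 12000 nM.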

Compound 4, half-maximal inhibitory concentration: 9660 nM
Estimate against measurement, compound 4: 1.9-fold (0.29 log units) below; low and high end bracket the measured number.
By their numbers in this assay, from the lowest: compounds 3, 2, 4 and 1 (each within the scatter of the next, the first and the last beyond it).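

In this assay, the exchange of the six-membered aromatic ring of carbon only for a ring with a hetero atom on this carbon gives a 2.5-fold higher number from compound 3 to compound 4 (0.40 log units; beyond the scatter) but only a 1.4-fold higher number from compound 2 to compound 4 (0.15 log units; within the scatter) from the other methoxyphenyl isomer. Pyridin-3-yl is thus separated from 3-methoxyphenyl alone, while a 1.0-fold lower number from compound 1 to compound 4 (0.00 log units; within the scatter) shows no separation from the group in compound 1. No measurement available here accounts for this difference.

Still open, as far as these compounds go, is how a phenyl ring carrying an amine or a carboxylic acid would read on this carbon. Pyridin-4-yl at the same place also remains untested in these compounds.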